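Cytotoxicity notes on the biaryl amide series

This account rests on a few compounds, and the source may have more. Where it says the series, first, only, none or still open, it means among the compounds named here.

In an ADME assay on Raji cells (Homo sapiens) for cytotoxicity, read by CellTiter-Glo and resazurin assay, with a stated time of 72 h (a higher number here means that more compound is needed for the effect, a lower number that less compound is needed), compound 3 `CCOC(=O)CCCCCOc1cccc(CN(C(=O)c2ccc(-c3ccoc3)cc2)C(C)C)c1` sits at the limit of the assay, > 26000 nM, and not at a measured number. Compound 2 `CCOC(=O)CCCCCOc1cccc(CN(C(=O)c2ccc(-c3cccnc3)cc2)C(C)C)c1` likewise gives only the limit > 26000 nM there. Compound 1 `CC(C)N(Cc1cccc(OCCCCCC(=O)O)c1)C(=O)c1ccc(-c2ccc3cc[nH]c3c2)cc1` also gives only the limit > 26000 nM in this assay. The one step among these, a step that the two limits leave unreadable from compound 2 to compound 3, cannot be read in size, and the same holds for the series as a whole, since (the limit of > 26000 nM in this assay, at which 3 of the 3 values shown sit). Compound 4 `CCOC(=O)CCCCCOc1cccc(CN(C(=O)c2ccc(-c3ccc4cc[nH]c4c3)cc2)C(C)C)c1` differs from compound 3 by 1H-indol-6-yl in place of furan-3-yl on an aromatic carbon. Among the compounds with values here, the group that enters is the one already carried by compound 1, whose reading in this assay is a limit. Within the data shown here, no measured step bears on this change in a readable way, and none of the three readings offers a direction. The expected step that the limit leaves unreadable from compound 3 to compound 4 is therefore none beyond the scatter, with the reading most likely again a limit. Compound 4 is estimated at 30000 nM, within 15000 nM to 100000 nM.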

Compound 4, half-maximal effective concentration: > 26000 nM
Compound 4: no number, only a limit; the forecaster's own chance of this, stated with the estimate: 85%; the middle value is on the limit's open side.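

Compound 4 again gives only a limit in this assay, and no step to it from compound 1, compound 2 or compound 3 can be read: the limit of > 26000 nM in this assay, at which 4 of the 4 values shown sit.

The compounds shown leave open at what concentration any of them produces the effect, and whether any change among them shifts it.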